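Shortening the ester chain once more within a series at its limit

The compounds below may be only part of what the source reports. "The series", "measured", "known", "first", "only" and "open" are said of these compounds alone.

Compound 2 `CCCCCCCCCCC(=O)OCCc1ccc(O)c(O)c1` bears the shared core with an ester chain. In a toxicity assay on MRC5 cells (Homo sapiens) for inhibition, read by MTT assay, with a stated time of 72 h (on this read-out higher numbers stand for weaker inhibition and lower numbers for stronger inhibition), compound 2 gives > 50000 nM, which is a limit of the assay and not a number. Compound 1 `CCCCCCCCCCCCCCCC(=O)OCCc1ccc(O)c(O)c1` differs from compound 2 only in that chain. In this assay compound 1 gives > 50000 nM, again a limit. Compound 3 `CC(=O)OCCc1ccc(O)c(O)c1` carries the shortest chain of the set. In this assay compound 3 gives > 50000 nM, once more a limit. Among the compounds with values here, the single step between measured neighbours, a step that the two limits leave unreadable from compound 1 to compound 2, cannot be sized because of the limit of > 50000 nM in this assay, at which 3 of the 3 values shown sit. Compound 4 `CCCCCCCCCC(=O)OCCc1ccc(O)c(O)c1` differs from compound 2 by hydrogen in place of methyl on a saturated chain carbon, nine bonds along the chain from a carbonyl carbon. Within the data shown here, this change is smaller than the one from compound 1 to compound 2 and falls between compound 2 and compound 3, both of which sit at the same limit, so no shift beyond the scatter in this assay is expected, and the expected step from compound 2 to compound 4 is a step that the limit leaves unreadable from compound 2 to compound 4. Compound 4 is therefore estimated at 80000 nM, with a range from 40000 nM to 200000 nM, most likely reported only as a limit.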

Compound 4, half-maximal inhibitory concentration: 71100 nM
Beside the measured number, compound 4's estimate is 1.1-fold (0.05 log units) above it; measured number inside the range.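

Within the data shown here, no step to compound 4 can be read in this assay, neither from compound 2 nor from compound 1, because both of those compounds stand only as limits: the limit of > 50000 nM in this assay, at which 3 of the 4 values shown sit. The compounds shown leave open whether the length of the ester chain changes this read-out at all.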